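A few compounds are considered here, and "the series" means these few. Any claim that something is new, unique, unknown or untested is made for them only; others in the source may bear on it.

In a functional assay on BHK-21 cells (Mesocricetus auratus) for cytotoxicity, read by MTT assay (a higher number here means that more compound is tolerated, a lower number that less compound is tolerated), compound 1 `CC(C)(C)C(=O)N1N=C(c2cccs2)CC1c1ccc(Cl)cc1` gives 90000 nM and compound 2 `CC(C)(C)C1=NN(C(=O)c2ccccc2)C(c2ccc(Cl)cc2)C1` gives 65000 nM, and these two numbers lie within the scatter of each other. Compound 3 `CC(C)(C)C(=O)N1N=C(C(C)(C)C)CC1c1ccc(Cl)cc1` differs from compound 2 on a carbonyl carbon whose other neighbours are an amide-type nitrogen in a ring, where tert-butyl stands in place of phenyl (tert-butyl in place of phenyl on a carbonyl carbon). Among the compounds with values here, no measured pair shows this change alone, but compound 1 already carries the (tert-butyl)carbonyl and gives 90000 nM in this assay as well. No shift beyond the scatter is therefore expected, and the estimated step stays small (a 1.2-fold higher number from compound 2 to compound 3 (0.09 log units; within the scatter)). For compound 3 the expected value is 80000 nM (estimated range 35000 nM to 180000 nM).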

Compound 3, half-maximal cytotoxic concentration: 60000 nM
For compound 3 the middle estimate is 1.3-fold (0.12 log units) above the measured one; measured number inside the range.
By their numbers in this assay, from the lowest: compounds 3, 2 and 1 (each within the scatter of the next).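

On the carbonyl carbon, tert-butyl can stand in place of phenyl while this assay stays within the scatter (a 1.1-fold lower number from compound 2 to compound 3 (0.03 log units; within the scatter)). On the carbon with a double bond to nitrogen, tert-butyl in place of thiophen-2-yl also stays within the scatter (a 1.5-fold lower number from compound 1 to compound 3 (0.18 log units; within the scatter)). Nothing available gives a reason for either result. The compounds shown leave open whether an amine or a carboxylic acid on the carbonyl carbon would also stay within the scatter. They also leave open whether a longer chain on the carbon with a double bond to nitrogen would do so.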